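The compounds below may be only part of what the source reports. "The series", "measured", "known", "first", "only" and "open" are said of these compounds alone.

Three compounds from this study share one core, and all three have been run in a functional assay on MGC-803 cells (Homo sapiens) for inhibition, read by sulforhodamine B assay, with a stated time of 72 h, tested at 10 uM; on this read-out higher numbers stand for more inhibition at the one concentration tested (going by the name of the read-out) and lower numbers for less inhibition. Compound 1, `O=C(/C=C/c1cccc(Br)n1)c1ccc(Nc2cc(-c3ccccc3)nc3nc(SCc4ccccc4)nn23)cc1`, gives 38.3% in this assay. Compound 2, `Cc1cc(Nc2ccc(C(=O)/C=C/c3cccc(Br)n3)cc2)n2nc(SCc3ccc(F)cc3)nc2n1`, gives 93.3% in this assay. Compound 3, `Cc1cc(Nc2ccc(C(=O)/C=C/c3ccc(Br)cn3)cc2)n2nc(SCc3nc4ccccc4[nH]3)nc2n1`, gives 96.8% in this assay. On these numbers compound 2 and compound 3 sit within the scatter of each other, so no order between them can be read, while compound 1 stands well below both, beyond the scatter.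

Compound 4, `Cc1cc(Nc2ccc(C(=O)/C=C/c3cccc(Br)n3)cc2)n2ncnc2n1`, has not yet been measured. It differs from compound 2 in one place: hydrogen in place of (4-fluorobenzyl)sulfanyl on an aromatic carbon. Going by the values given here, no measured pair in this set isolates this change, so the size of the step in this assay has to be estimated rather than read from a neighbouring pair. Since compound 2 gives 93.3% and the change removes the whole (4-fluorobenzyl)sulfanyl group, a step downward beyond the scatter is expected for compound 4, though with wide uncertainty. Compound 4 is therefore expected to give about 65% in this assay, within a range from 30% to 92%, which corresponds to an expected step of a number 28.3 percentage points lower from compound 2 to compound 4 (beyond the scatter).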

Compound 4, a percentage reported as inhibition, at one concentration (the size of the read-out at that concentration, not a potency): 58.4%
For compound 4 the middle estimate is 6.6 percentage points above the measured one, and the stated range covers the measured number.
By their numbers in this assay, from the lowest: compound 1; then compound 4; then compounds 2 and 3 (each within the scatter of the next).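

In this assay, going by these compounds alone, replacing the (4-fluorobenzyl)sulfanyl group with hydrogen on this aromatic carbon gives a number 34.9 percentage points lower from compound 2 to compound 4 (beyond the scatter), the first change in this set that can be read at a single place, and it shows that the group on this carbon counts towards the read-out. Compound 4 still gives 58.4%, so the (4-fluorobenzyl)sulfanyl group is not needed for some inhibition to appear at the one concentration tested, although its presence goes with a higher number. No measurement of any kind is at hand to explain the size of this step.

The compounds shown do not tell which part of the departing group carries the step: the sulfur, the benzyl ring or the fluorine, a question that a methylsulfanyl group, an unsubstituted benzylsulfanyl group or an amine on the same carbon would start to separate. They also leave open how the step would look across a range of concentrations, since a single-concentration percentage gives a size and not a potency.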